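Urea series: azole exchange on the weak ester compound 2

This account rests on a few compounds, and the source may have more. Where it says the series, first, only, none or still open, it means among the compounds named here.

Measured so far:
compound 1 `CN(Cc1ccccc1)S(=O)(=O)c1ccc(NC(=O)NCc2ccncc2)cc1`: 23 nM
compound 2 `CCOC(=O)c1ccc(NC(=O)NCc2cocn2)cc1`: 27600 nM

Both compounds share the phenylurea core; they differ on the aryl substituent as well as on the group attached to the urea methylene. In an assay on isolated protein for activation of Nicotinamide phosphoribosyltransferase (Homo sapiens) (a lower number here means that less compound is needed, a higher number that more compound is needed for the effect), compound 1 gives 23 nM. In this assay compound 2 gives 27600 nM, the highest of the two numbers; its gap to compound 1 lies well beyond the scatter. Compound 1 and compound 2 differ in more than one place. The pair says nothing about which of the two changes carries the loss.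

Compound 3 `CCOC(=O)c1ccc(NC(=O)NCc2c[nH]nn2)cc1` carries 1H-1,2,3-triazol-4-yl in place of 1,3-oxazol-4-yl on a saturated chain carbon bound to an amide-type nitrogen. Among the measured compounds shown here, no measured pair in the set isolates a change of this kind, so the size of the step cannot be taken from data; with the ester retained, the step is expected to be small, most likely none beyond the scatter, with a slight lean towards a lower number. Compound 3 is therefore expected at 20000 nM, within 5000 nM to 70000 nM. The expected step is a 1.4-fold lower number from compound 2 to compound 3 (0.14 log units; within the scatter).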

Compound 3, half-maximal effective concentration: 7750 nM
The estimate for compound 3 lay 2.6-fold (0.41 log units) above the measured number; low and high end bracket the measured number.
By their numbers in this assay, from the lowest: compound 1; then compound 3; then compound 2.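

In this assay the group on a saturated chain carbon bound to an amide-type nitrogen moves the number on its own, which the pair of compound 1 and compound 2 could not show: the exchange of 1,3-oxazol-4-yl for 1H-1,2,3-triazol-4-yl gives a 3.6-fold lower number from compound 2 to compound 3 (0.55 log units; beyond the scatter) with the ethyl ester unchanged. The exchange keeps the five-membered aromatic ring, the 5 heavy atoms and the 2 hydrogen-bond acceptors, while the entering group adds 1 hydrogen-bond donor, although this single pair cannot tie the step to that donor. Nothing available bears on why the number moves.

On these data alone, it remains open whether a step of this size persists when the ethyl ester is replaced by a carboxylic acid or by the sulfonamide group of compound 1, and how 1H-imidazol-4-yl would compare in the same place. The shares of the aryl substituent and the group on the urea methylene in the gap between compound 1 and compound 2 also remain unassigned.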